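The source may report more compounds than this note shows. Statements on the series, on what has been measured and on what is new or still open speak of the compounds shown alone.

Of the compounds shown here, three built on a shared core have been tested in a functional assay on MDA-MB-231 cells (Homo sapiens) for inhibition, read by MTT assay, with a stated time of 72 h; on this read-out lower numbers stand for stronger inhibition and higher numbers for weaker inhibition. Compound 1 `CCN(CC)CCCn1c(=O)c(=Cc2ccc(O)cc2)s/c1=C1\C(=O)Nc2ccc(C)cc21` gives 1810 nM, the lowest of the three numbers. Compound 2 `CN(C)CCn1c(=O)c(=Cc2ccc(F)c(F)c2)s/c1=C1\C(=O)Nc2ccc(F)cc21` gives 9480 nM, and compound 3 `Cc1ccc2c(c1)/C(=c1/sc(=Cc3ccc(C=O)c(C=O)c3)c(=O)n1CCN(C)C)C(=O)N2` gives 8100 nM; both lie beyond the scatter above compound 1, so compound 1 is the most potent of the measured set.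

Compound 4 `CCN(CC)CCCn1c(=O)c(=Cc2ccccc2O)s/c1=C1\C(=O)Nc2ccc(C)cc21` has not yet been measured. It has the same atoms as compound 1, joined differently: 2-hydroxyphenyl in place of 4-hydroxyphenyl on a double-bonded chain carbon bound to an aromatic carbon. Going by the values given here, no pair of measured compounds differs in a single place, so the effect of such a change cannot be read from the measured numbers; compound 2 and compound 3 differ from compound 1 in more than one place at once, and their values show only that combined changes move the read-out well beyond the scatter.

The step from compound 1 to compound 4 in this assay is expected to be small, toward a higher number, near the edge of the scatter: a 1.5-fold higher number from compound 1 to compound 4 (0.17 log units; within the scatter). Compound 4 is therefore estimated to give about 2700 nM, with a likely range from 900 nM to 8000 nM.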

Compound 4, half-maximal inhibitory concentration: 15900 nM
Beside the measured number, compound 4's estimate is 5.9-fold (0.77 log units) below it, outside the stated range (above it).
By their numbers in this assay, from the lowest: compound 1; then compounds 3, 2 and 4 (each within the scatter of the next).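

In this assay, 2-hydroxyphenyl in place of 4-hydroxyphenyl on a double-bonded chain carbon bound to an aromatic carbon gives an 8.8-fold higher number from compound 1 to compound 4 (0.94 log units; beyond the scatter). Going by these compounds alone, this is the first change in the set made in one place only, and it shows that the read-out at this position depends on where the hydroxy group sits on the ring, even though the two compounds have the same atoms. The data shown offer no measured explanation for this step.

The compounds shown leave open whether a plain phenyl group or a methoxyphenyl group at this place would give a number closer to that of compound 1 or to that of compound 4. They also leave open whether the same hydroxy shift would have a similar effect on a core carrying a dimethylaminoethyl chain.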